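Swapping a Thiourea for a Sulfonyl Group on the Piperazine

This account rests on a few compounds, and the source may have more. Where it says the series, first, only, none or still open, it means among the compounds named here.

Compound 1 `COc1cc2nc(N3CCN(C(=O)CCc4ccccc4)CC3)nc(N)c2cc1OC` carries a shared core and, in an assay for binding affinity to Adrenergic receptor alpha-1 (Rattus norvegicus) (a higher number here means a weaker inhibitor, a lower number a stronger inhibitor), compound 1 gives 3.39 nM. Compound 2 `COc1cc2nc(N3CCN(/C(S)=N/C4CCCCC4)CC3)nc(N)c2cc1OC` differs in one place, and in this assay compound 2 gives 5.37 nM. The change is a 1.6-fold higher number from compound 1 to compound 2 (0.20 log units; within the scatter), so compound 2 and compound 1 lie within the scatter of each other and neither can be called the stronger binder.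

Compound 3 `COc1cc2nc(N3CCN(S(=O)(=O)c4ccc(C)cc4)CC3)nc(N)c2cc1OC` takes the next step: a group of 10 heavy atoms (7 carbon, 2 oxygen, 1 sulfur; one six-membered aromatic ring of carbon only) in place of a group of 9 heavy atoms (7 carbon, 1 nitrogen, 1 sulfur; one six-membered non-aromatic ring of carbon only), on an amine nitrogen in a ring. Among the measured compounds shown here, only the step from compound 1 to compound 2 bears on this, as it also exchanged the whole group on that ring nitrogen, and it stayed within the scatter. A similar outcome is therefore expected, with at most a slight move toward a higher number, a 1.7-fold higher number from compound 2 to compound 3 (0.22 log units; within the scatter). Compound 3 is expected to give about 9 nM, likely between 2.5 nM and 35 nM.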

Compound 3, half-maximal inhibitory concentration: 11.5 nM
The estimate for compound 3 lay 1.3-fold (0.11 log units) below the measured number; low and high end bracket the measured number.
By their numbers in this assay, from the lowest: compounds 1 and 2 (each within the scatter of the next); then compound 3.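

Unlike the first exchange on this amine nitrogen in a ring, the move to (4-methylphenyl)sulfonyl shifts the number beyond the scatter in this assay: the change is a 2.1-fold higher number from compound 2 to compound 3 (0.33 log units; beyond the scatter) and, measured against the other starting point, a 3.4-fold higher number from compound 1 to compound 3 (0.53 log units; beyond the scatter). Both steps are modest, so the position accepts three very different groups, yet it does not treat them all alike, and compound 3 is the weakest binder of the three. Nothing available here points to a reason for this shift.

From the compounds shown here alone, the sulfonyl link and the 4-methylphenyl ring arrive together in one step, so it stays open which of them carries the shift. Also open, going by these compounds, is how a chain ending in an amine or a carboxylic acid would fare on this nitrogen.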